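Replacing a chloro-thiazole with a bromo-pyridine on the sulfonyl

A few compounds are considered here, and "the series" means these few. Any claim that something is new, unique, unknown or untested is made for them only; others in the source may bear on it.

Compound 1 `CC1CCN(C2CCN(S(=O)(=O)c3sc(Cl)nc3C3CC3)CC2)CC1` gives > 5000 nM in a functional assay on DLD-1 cells (Homo sapiens) for antiproliferative activity, read by CellTiter-Glo, with a stated time of 72 h (a higher number here means a weaker inhibitor, a lower number a stronger inhibitor), which is a limit of the assay rather than a number.
Compound 2 `CC1CCN(C2CCN(S(=O)(=O)c3cnc(Cl)s3)CC2)CC1` gives 1800 nM in this assay.
Compound 3 `CC1CCN(C2CCN(S(=O)(=O)c3ccccc3-c3ccccc3)CC2)CC1` gives 0.96 nM in this assay.

Among the two numbers measured, compound 2 stands highest, with compound 3 far below it. Going by the values given here, the only step measured in one place is an at least 2.7-fold lower number from compound 1 to compound 2 (0.44 log units; beyond the scatter), where the ring on the sulfonyl sulfur stayed the same and only a substituent on it changed; the limit of > 5000 nM in this assay, at which 1 of the 3 values shown sits, reminds that one of the three values is a limit, so the size of that step is itself a lower bound. Compound 4 `CC1CCN(C2CCN(S(=O)(=O)c3cncc(Br)c3)CC2)CC1` arises from compound 2 by 5-bromopyridin-3-yl in place of 2-chloro-1,3-thiazol-5-yl on a sulfonyl sulfur. Among the compounds with values here, no measured step swaps the whole aromatic ring on the sulfonyl sulfur, so the direction rests on the gap between compound 2 and compound 3, which shows that a different group in this position can bring the number down sharply. A modest downward step is therefore expected, a 3.0-fold lower number from compound 2 to compound 4 (0.48 log units; beyond the scatter), with wide uncertainty. The estimate for compound 4 is 600 nM, ranging from 60 nM to 5000 nM.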

Compound 4, half-maximal inhibitory concentration: > 5000 nM
Compound 4 ended at the assay's limit (the forecaster's own chance of this, stated with the estimate: 20%); middle value at least 8.3-fold (0.92 log units) away from the limit.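

Going by these compounds alone, this is the one measured swap of the whole aromatic ring on the sulfonyl sulfur, and it moves the number up: an at least 2.7-fold higher number from compound 2 to compound 4 (0.44 log units; beyond the scatter). A new aromatic ring at this place therefore does not bring the number down by itself, and the low value of compound 3, which gives 0.96 nM in this assay, does not carry over to 5-bromopyridin-3-yl. Compound 4 gives > 5000 nM, which is a limit of the assay and not a number, so the step shows only the least possible size of the change: the limit of > 5000 nM in this assay, at which 2 of the 4 values shown sit.

From the compounds shown here alone, it stays open whether an amine or a carboxylic acid in place of the bromine on 5-bromopyridin-3-yl would bring the number under the limit. Going by these compounds, it is equally open whether a phenyl group there would move it towards the value of compound 3.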